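A few compounds are considered here, and "the series" means these few. Any claim that something is new, unique, unknown or untested is made for them only; others in the source may bear on it.

Compound 3 `CCCn1c(=O)c2nc(C3CCNCC3)[nH]c2n(CCC)c1=O` stands at the weak end of the three measurements in an assay on membranes from brain for antagonist activity at adenosine receptor A1 (Rattus norvegicus); on this read-out lower numbers stand for stronger inhibition and higher numbers for weaker inhibition. In this assay compound 3 gives 620 nM, the highest of the three numbers. Compound 1 `CCCn1c(=O)c2nc(-c3ccc(OCC(=O)OCC)cc3O)[nH]c2n(CCC)c1=O` gives 31 nM in this assay, and compound 2 `CCCn1c(=O)c2nc(-c3ccc(OCC(=O)NCCN)cc3O)[nH]c2n(CCC)c1=O` gives 2.4 nM. For the measured compounds named here, the only step between two measured compounds that differ in one place, a 13-fold lower number from compound 1 to compound 2 (1.11 log units; beyond the scatter), concerns the chain on the aryl ether and not the group attached to the shared core.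

Compound 4 `CCCn1c(=O)c2nc(-c3cnccn3)[nH]c2n(CCC)c1=O` is obtained from compound 3 by the change (pyrazin-2-yl in place of piperidin-4-yl on an aromatic carbon). Going by the values given here, no measured step bears on this exchange, since the one recorded step leaves the group attached to the core untouched. What can be said is that compound 1 and compound 2, both of which carry an aromatic ring at that position, give the two lower numbers in this assay, whereas compound 3 with its non-aromatic ring gives the highest.

On that basis a lower number for compound 4 than for compound 3 is expected, with the step of a 10-fold lower number from compound 3 to compound 4 (1.01 log units; beyond the scatter) estimated in this assay. The value for compound 4 is estimated at 60 nM, within a range from 10 nM to 350 nM.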

Compound 4, antagonist equilibrium constant: 600 nM
Compound 4: the middle estimate sits 10-fold (1.00 log units) below what was measured, and the stated range ends below it.
By their numbers in this assay, from the lowest: compound 2; then compound 1; then compounds 4 and 3 (each within the scatter of the next).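

In this assay, placing pyrazin-2-yl instead of piperidin-4-yl on this aromatic carbon between two ring nitrogen atoms gives a 1.0-fold lower number from compound 3 to compound 4 (0.01 log units; within the scatter), so the two groups are not told apart here. A six-membered aromatic ring with 2 hetero atoms therefore does no better at this position than a six-membered non-aromatic ring with 1 hetero atom, which shows that an aromatic ring in this place is not enough on its own to give a lower number. The exchange also removes the hydrogen-bond donor of the piperidin-4-yl group and adds a hydrogen-bond acceptor without moving the number beyond the scatter, and no supporting data are available to explain this outcome.

The compounds shown leave open whether the lower numbers of compound 1 and compound 2 depend on the hydroxy group on their aryl ring, on the ether chain, or on the two together. They also cannot tell how an unsubstituted phenyl ring would read at this position, or whether a 2-aminoethyl amide chain would lower the number if carried on pyrazin-2-yl.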